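Amino in Place of Methyl: From Compound 2 to Compound 4

A few compounds are considered here, and "the series" means these few. Any claim that something is new, unique, unknown or untested is made for them only; others in the source may bear on it.

The three measured compounds share the core of compound 3 `O=C(O)CCc1ccc(C#Cc2ccccc2)cc1`, which in an in vitro functional assay on 1321-N1 cells for agonist activity at Free fatty acid receptor 1 (Homo sapiens), read by fluorescence (on this read-out higher numbers stand for an effect only at larger amounts of compound and lower numbers for an effect already at smaller amounts), gives 95.5 nM; 96 nM (2 entries), a figure that rests on (the several entries of compound 3 in this assay, 95.5 nM; 96 nM (2 entries)). Compound 1 `O=Cc1cccc(C#Cc2ccc(CCC(=O)O)cc2)c1` carries a formyl group and gives 355 nM, while compound 2 `Cc1cccc(C#Cc2ccc(CCC(=O)O)cc2)c1` carries a methyl group at the same place and gives 43.7 nM. For the measured compounds named here, the step of an 8.1-fold lower number from compound 1 to compound 2 (0.91 log units; beyond the scatter) is the only one-place change with a measured size. Among the single numbers shown, compound 2 stands lowest; its nearest neighbour is compound 1, and compound 3 enters only through its pair of entries, which fall between the other two.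

Compound 4 `Nc1cccc(C#Cc2ccc(CCC(=O)O)cc2)c1` is not yet measured. It differs from compound 2 by amino in place of methyl on an aromatic carbon. The step of an 8.1-fold lower number from compound 1 to compound 2 (0.91 log units; beyond the scatter) concerns formyl rather than amino, so it bears on the new change only loosely; compound 3, with no group at that place, gives a number between those of compound 1 and compound 2. An upward step of modest size is therefore expected, short of that seen with formyl. Compound 4 is estimated at 150 nM, within 50 nM to 500 nM. That expectation corresponds to a 3.4-fold higher number from compound 2 to compound 4 (0.54 log units; beyond the scatter).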

Compound 4, half-maximal effective concentration: 1100 nM
For compound 4 the middle estimate is 7.3-fold (0.87 log units) below the measured one; the whole stated range lies below it.
By their numbers in this assay, from the lowest: compound 2; then compound 1; then compound 4.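

Amino in place of methyl on an aromatic carbon gives a 25-fold higher number from compound 2 to compound 4 (1.40 log units; beyond the scatter), a large step where the earlier change at this place was modest. Formyl no longer marks the high end of the numbers at this place, for amino gives a 3.1-fold higher number from compound 1 to compound 4 (0.49 log units; beyond the scatter), so the two groups that replace methyl here both raise the number, and amino does so the more. Amino brings a hydrogen-bond donor and a hydrogen-bond acceptor where methyl brings neither, but nothing measured here accounts for the size of the step.

The compounds shown leave open whether a hydroxyl or a methoxy group at this place would stay close to methyl or move towards amino, and whether a dimethylamino group would follow amino. They also leave open whether amino in place of methyl would cost as much elsewhere on the six-membered aromatic ring.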